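Hydrogen for hydroxy on compound 2: cytotoxicity notes

The source may report more compounds than this note shows. Statements on the series, on what has been measured and on what is new or still open speak of the compounds shown alone.

Measured in an ADME assay on HEK293 cells (Homo sapiens) for cytotoxicity, with a stated time of 72 h (a higher number here means that more compound is needed for the effect, a lower number that less compound is needed), and each reported as a limit:

compound 1 `Cc1ccc(-c2nc3ccccc3s2)cc1NC(=O)c1cc([N+](=O)[O-])c(N2CCC(C(=O)O)CC2)cc1Cl` | > 25000 nM (limit)
compound 2 `O=C(Nc1cccc(-c2nc3ccccc3s2)c1)c1cc([N+](=O)[O-])c(O)cc1Cl` | > 25000 nM (limit)
compound 3 `O=C(Nc1nc2c(Cl)cccc2s1)c1cc([N+](=O)[O-])ccc1Cl` | > 27000 nM (limit)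

Compound 2 stands at > 25000 nM in this assay and this is a limit, not a number. The other values are limits too, with the limit of > 25000 nM in this assay, at which 2 of the 3 values shown sit, and the limit of > 27000 nM in this assay, at which 1 of the 3 values shown sits, making up the whole set. Compound 4 `O=C(Nc1cccc(-c2nc3ccccc3s2)c1)c1cc([N+](=O)[O-])ccc1Cl` carries hydrogen in place of hydroxy on an aromatic carbon, ortho to a nitro group. Compound 3 also lacks the hydroxy and gives > 27000 nM as its limit in this assay here. Among the measured compounds shown here, no step between measured compounds gives a size for this change. The expected a number no higher from compound 2 to compound 4 (the limit leaves the size open) stays within the scatter, with no direction foreseen. For compound 4 the estimated value is 25000 nM with an expected range from 12000 nM to 50000 nM and a limit is likely.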

Compound 4, half-maximal effective concentration: > 27000 nM
Compound 4: only a limit was reported; the forecaster's own chance of this, stated with the estimate: 85%; at least 1.0-fold (0.03 log units) between middle value and limit.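

Among the compounds shown here, compound 2 and compound 4 are both reported only as limits, so no step between them can be read. The compounds shown leave open whether hydrogen in place of hydroxy shifts the value in this assay at all, as every value shown is a limit.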